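This account rests on a few compounds, and the source may have more. Where it says the series, first, only, none or still open, it means among the compounds named here.

Measured compounds:
- compound 1, `CN(C)CCn1cnnc1-c1cc(Oc2ccc(NC(=O)N/N=C/c3c(Cl)cccc3Cl)cc2F)ccn1`: > 100000 nM in a functional assay on U-87MG ATCC cells (Homo sapiens) for cytotoxicity, read by MTT assay, with a stated time of 72 h; a lower number here means a stronger inhibitor, a higher number a weaker inhibitor
- compound 2, `COc1ccc(OC)c(/C=N/NC(=O)Nc2ccc(Oc3ccnc(-c4nncn4CCN(C)C)c3)c(F)c2)c1`: 6400 nM in this assay

In this assay compound 1 gives only a limit, not a number, and that value sits at the limit of > 100000 nM in this assay, at which 1 of the 2 values shown sits. Among the measured compounds shown here, compound 2 is therefore the only compound here with a measured number; the other value shown beside it is that limit. For the measured compounds named here, the one measured step, an at least 15-fold lower number from compound 1 to compound 2 (1.19 log units; beyond the scatter), shows that exchanging the aromatic group on the carbon with a double bond to nitrogen can move the readout strongly.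

Compound 3, `CN(C)CCn1cnnc1-c1cc(Oc2ccc(NC(=O)N/N=C/c3ccc(O)c(O)c3)cc2F)ccn1`, has not yet been measured in this assay. It differs from compound 2 in this way: 3,4-dihydroxyphenyl in place of 2,5-dimethoxyphenyl on a carbon with a double bond to nitrogen. The step from compound 1 to compound 2 bears on this position, and it was large, but it shows only that this position is sensitive, not which way a 3,4-dihydroxyphenyl group would move the number. The expected step is therefore uncertain in direction, a 1.6-fold higher number from compound 2 to compound 3 (0.19 log units; within the scatter). Compound 3 is expected to give about 10000 nM, within a range from 2000 nM to 60000 nM.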

Compound 3, half-maximal inhibitory concentration: > 100000 nM
Compound 3: no number, only a limit; the forecaster's own chance of this, stated with the estimate: 30%; middle value at least 10-fold (1.00 log units) from the limit.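

In this assay, putting 3,4-dihydroxyphenyl in place of 2,5-dimethoxyphenyl gives an at least 15-fold higher number from compound 2 to compound 3 (1.19 log units; beyond the scatter), so this change, unlike the earlier step, moves the readout away from a measured number rather than towards one. Among the three groups shown on the carbon with a double bond to nitrogen, only 2,5-dimethoxyphenyl gives a measured number, so a substituted phenyl ring there does not by itself ensure one. Compound 1 and compound 3 both give only limits, and the step between them cannot be read: the limit of > 100000 nM in this assay, at which 2 of the 3 values shown sit.

This change alters both the kind of group on the ring and where the groups sit, and the compounds shown cannot separate the two. A 3,4-dimethoxyphenyl or a 2,5-dihydroxyphenyl group would be needed to tell these apart.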